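Cytotoxicity of a Styryl Cyclohexenone: An Added Methoxy

A few compounds are considered here, and "the series" means these few. Any claim that something is new, unique, unknown or untested is made for them only; others in the source may bear on it.

Measured so far:
compound 1 `COc1ccc(/C=C/Cc2ccc(O)c(OC)c2OC)cc1O`: 79000 nM
compound 2 `O=C1C=C[C@](O)(C/C=C/c2ccccc2)CC1`: 55700 nM

In a functional assay on HeLa cells (Homo sapiens) for cytotoxicity, read by fluorescence and sulforhodamine B assay (on this read-out higher numbers stand for weaker inhibition and lower numbers for stronger inhibition), compound 1 gives 79000 nM and compound 2 gives 55700 nM. Compound 2 carries the lower of the two numbers, though its gap to compound 1 lies within the scatter, so nothing is made of that. Compound 3 `COc1ccccc1/C=C/C[C@@]1(O)C=CC(=O)CC1` differs from compound 2 by methoxy in place of hydrogen on an aromatic carbon. Among the compounds with values here, no step between measured compounds covers a change of this kind, so no step beyond the scatter is expected in this assay in either direction; the expected step from compound 2 to compound 3 is a 1.1-fold lower number from compound 2 to compound 3 (0.05 log units; within the scatter). Compound 3 is estimated at 50000 nM, within 20000 nM to 120000 nM.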

Compound 3, half-maximal inhibitory concentration: 54200 nM
The estimate for compound 3 lay 1.1-fold (0.04 log units) below the measured number, within the range that was stated.
By their numbers in this assay, from the lowest: compounds 3, 2 and 1 (each within the scatter of the next).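

In this assay the exchange of hydrogen for methoxy on an aromatic carbon, ortho to a large group, brings a 1.0-fold lower number from compound 2 to compound 3 (0.01 log units; within the scatter) and so shows that, at this position, this group produces no step beyond the scatter. This is the first change on the aromatic ring among these compounds, and no measurement shown here offers an explanation for the result. Still open, on these data alone, is whether an amine, a carboxylic acid or a longer alkoxy chain at this position would move the number beyond the scatter.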